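The compounds below may be only part of what the source reports. "The series", "measured", "known", "first", "only" and "open" are said of these compounds alone.

Measured compounds:
Compound 1 `CN(C)CCCCCSC1=Nc2ccccc2C(CC(=O)NCc2ccccc2)N1c1ccc(-c2ccc(F)cc2)cc1` — 75.6%
Compound 2 `O=C(CC1c2ccccc2N=C(SCCCCCN2CCCC2)N1c1ccc(-c2ccccc2)cc1)NCc1ccc(F)cc1` — 69%
Compound 3 `O=C(CC1c2ccccc2N=C(SCCCCCN2CCCC2)N1c1ccc(-c2ccc(F)cc2)cc1)NCc1ccccc1` — 97.5%

Within the data shown here, in an assay on cells for inhibition of Voltage-dependent T-type calcium channel subunit alpha-1H (Homo sapiens), read by patch clamp, tested at 10 uM (a higher number here means more inhibition at the concentration tested (going by the name of the read-out), a lower number less inhibition), compound 3 stands highest of the three: compound 1 sits a number 21.9 percentage points higher from compound 1 to compound 3 (beyond the scatter) below it, the only single-place step among the measured compounds, and that step changes the amine at the end of the chain, with hydrogen in place of 4-fluorophenyl on an aromatic carbon playing no part in it. Compound 2 differs from compound 3 in two places at once, so its value can only be set beside that of compound 3 without a step being drawn.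

Compound 4 `O=C(CC1c2ccccc2N=C(SCCCCCN2CCCC2)N1c1ccccc1)NCc1ccccc1` carries one change from compound 3: hydrogen in place of 4-fluorophenyl on an aromatic carbon. Among the measured compounds shown here, no measured pair varies this part of the structure, so nothing here tells how much the read-out in this assay depends on the group that leaves. For the measured compounds named here, the only step available, a number 21.9 percentage points higher from compound 1 to compound 3 (beyond the scatter), is modest and concerns a different place. Compound 4 is therefore expected to lose some inhibition, with a wide band of uncertainty, amounting to an estimated a number 37.5 percentage points lower from compound 3 to compound 4 (beyond the scatter). For compound 4 the estimate in this assay is 60%, with a range from 25% to 95%.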

Compound 4, a percentage reported as inhibition, at one concentration (the size of the read-out at that concentration, not a potency): 61.6%
The estimate for compound 4 lay 1.6 percentage points below the measured number; low and high end bracket the measured number.
By their numbers in this assay, from the lowest: compounds 4, 2 and 1 (each within the scatter of the next, the first and the last beyond it); then compound 3.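

In this assay, among these compounds, this is the first reading of the place on the aromatic carbon para to a large group: hydrogen in place of 4-fluorophenyl gives a number 35.9 percentage points lower from compound 3 to compound 4 (beyond the scatter). The read-out therefore depends on what sits at this place, and the step is large, whereas the change of amine, a number 21.9 percentage points higher from compound 1 to compound 3 (beyond the scatter), is modest. Even so, the group is not required for all inhibition at the concentration tested, since compound 4 still gives 61.6% in this assay, and nothing given here bears on what lies behind the step.

The single step removes the whole 4-fluorophenyl group, so it cannot separate the contribution of the fluorine from that of the six-membered aromatic ring that carries it, and no pair among the compounds shown isolates the fluorine at this place. From the compounds shown here alone, it remains open how much inhibition would be kept with a plain phenyl, a 4-chlorophenyl, a pyridyl ring or a small group such as methoxy at this place, or whether the step would keep its size with dimethylamino at the end of the chain.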